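The source may hold more compounds than are shown below. What is called first, only, known or untested is meant among the compounds shown, and "the series" means these compounds.

Measured compounds in the series:

compound 1, `CC#C[C@H]1CN(S(=O)(=O)c2ccc(N)nc2)CCN1c1ccc(S(=O)(=O)NC)cn1`, 42 mL.min-1.g-1
compound 2, `CC#C[C@H]1CN(S(=O)(=O)c2ccc(N)nc2)CCN1c1ccc(S(=O)(=O)NCC2CC2)cc1`, 213 mL.min-1.g-1
compound 3, `CC#C[C@H]1CN(S(=O)(=O)c2ccc(N)nc2)CCN1c1ccc(C(O)(C(F)(F)F)C(F)(F)F)cn1`, 42 mL.min-1.g-1

All three were read in an ADME assay (liver) for metabolic stability, with Liver microsome (Rattus norvegicus) as the target, using microsomes and NADPH, with a stated time of 30 min; a lower number here means slower removal, a higher number faster removal of the compound. Compound 2 stands highest of the three; compound 1 and compound 3 each sit a large gap below it, well beyond the scatter, and the two of them are indistinguishable from each other. Among the compounds with values here, the only measured single step, no change at the digits printed from compound 1 to compound 3 (within the scatter), concerns an exchange on the six-membered ring that carries a nitrogen, and it shows no movement.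

Compound 4, `CC#C[C@H]1CN(S(=O)(=O)c2ccc(N)nc2)CCN1c1ccc([S+](C)[O-])cc1`, is reached from compound 2 by a group of 3 heavy atoms (1 carbon, 1 oxygen, 1 sulfur; no ring) in place of a group of 8 heavy atoms (4 carbon, 1 nitrogen, 2 oxygen, 1 sulfur; one three-membered non-aromatic ring of carbon only), on an aromatic carbon. Within the data shown here, no measured step covers this change: the step from compound 1 to compound 3 sits on a different ring and swaps different groups, so it says little here beyond the fact that a change of substituent on that ring left the number flat. What the numbers do show is that compound 2, which alone carries the (cyclopropylmethyl)sulfamoyl group, is the only high reader. Taking that together with the loss of the larger group, a drop is expected, a 2.7-fold lower number from compound 2 to compound 4 (0.43 log units; beyond the scatter), though with wide uncertainty since nothing directly anchors it. Compound 4 is therefore estimated at 80 mL.min-1.g-1, in a range from 30 mL.min-1.g-1 to 210 mL.min-1.g-1.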

Compound 4, intrinsic clearance in microsomes: 17 mL.min-1.g-1
The estimate for compound 4 lay 4.7-fold (0.67 log units) above the measured number, and the stated range ends above it.
By their numbers in this assay, from the lowest: compound 4; then compounds 1 and 3 (each within the scatter of the next); then compound 2.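

In this assay, the exchange of (cyclopropylmethyl)sulfamoyl for a group of 3 heavy atoms, on an aromatic carbon of a six-membered aromatic ring of carbon only and para to a large group, gives a 13-fold lower number from compound 2 to compound 4 (1.10 log units; beyond the scatter) and is read as a large step. Within the data shown here, the only earlier single step, no change at the digits printed from compound 1 to compound 3 (within the scatter), sits on another ring and stayed flat, so this is the first measured sign that one substituent exchange can move the number, and that this position is not indifferent to what it carries. Among these compounds, no measurement accompanies the step that could tie it to any feature of either group, so the single pair gives a size and a direction but no explanation.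

The step removes the sulfamoyl unit and the cyclopropylmethyl chain together, and a methylsulfamoyl or unsubstituted sulfamoyl group at this place would show how much of it follows the cyclopropylmethyl alone. From the compounds shown here alone, whether the low number belongs to the entering group or simply to the loss of the larger one stays open, and a methylsulfonyl group or a simple amine at the same place would bear on that.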